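The compounds below may be only part of what the source reports. "The series", "measured", "known", "first", "only" and "open" are said of these compounds alone.

Measured compounds in an ADME assay on MCF-10A cells (Homo sapiens) for cytotoxicity, read by sulforhodamine B assay, with a stated time of 48 h; a lower number here means a stronger inhibitor of growth, a higher number a weaker inhibitor of growth:
- compound 1 `CCN(CC)CN1C(=O)/C(=N\c2nc3ccc(C)cc3s2)c2c(Br)cccc21`: 16100 nM
- compound 2 `O=C1C(=O)N(CN(c2ccccc2)c2ccccc2)c2cccc(Cl)c21`: 77200 nM
- compound 3 `CN(C)CN1C(=O)C(=O)c2c(Br)cccc21`: 67800 nM

Among these three, compound 1 gives the lowest number in this assay. The nearest value belongs to compound 3, whose number lies above that of compound 1 by a gap beyond the scatter; the furthest belongs to compound 2, also beyond the scatter. Compound 1 is thus the strongest growth inhibitor of the three in this assay. Going by the values given here, no pair among the measured compounds differs in only one place, so no single step can be read from them.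

Compound 4 `Cc1ccc2nc(/N=C3\C(=O)N(CN4CCCCC4)c4cccc(Br)c43)sc2c1` has not yet been measured in this assay. It differs from compound 1 in one place: piperidin-1-yl in place of diethylamino on a saturated chain carbon bound to an amide-type nitrogen in a ring. Cut one bond further out, the change reads (diethylamino)methyl to (piperidin-1-yl)methyl. The remainder of the structure, including the shared core and the imine-linked heteroaryl group, is unchanged.

Among the compounds with values here, with no comparable step among the measured compounds, the expectation rests on the small size of the change. The step from compound 1 to compound 4 in this assay is expected to be a 1.2-fold lower number from compound 1 to compound 4 (0.06 log units; within the scatter), that is, no change beyond the scatter. Compound 4 is therefore estimated at 14000 nM, with a range of 5000 nM to 40000 nM.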

Compound 4, concentration for 50% growth inhibition: 18400 nM
For compound 4 the middle estimate is 1.3-fold (0.12 log units) below the measured one; the measured number falls inside the stated range.
By their numbers in this assay, from the lowest: compounds 1 and 4 (each within the scatter of the next); then compounds 3 and 2 (each within the scatter of the next).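

In this assay, going by these compounds alone, the exchange of diethylamino for piperidin-1-yl on a saturated chain carbon bound to an amide-type nitrogen in a ring gives a 1.1-fold higher number from compound 1 to compound 4 (0.06 log units; within the scatter) and is the first single-place comparison. At this place, with the shared core and the imine-linked heteroaryl group held constant, the open diethylamino group and the six-membered non-aromatic ring of piperidin-1-yl are not separated by this read-out, although the heavy-atom count moves from 5 to 6 and the hydrogen-bond donor and acceptor counts stay the same. No measured property or other supporting data accompany this result to account for it.

On these data alone, whether the same flat reading holds for morpholin-4-yl, 4-methylpiperazin-1-yl or a longer chain carrying the amine at this place remains open. The part played by the imine-linked heteroaryl group, and by bromo as against chloro on the core, cannot be read from the compounds shown, as no single-place step covers either change.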